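Notes on the step from compound 3 to compound 4

This account rests on a few compounds, and the source may have more. Where it says the series, first, only, none or still open, it means among the compounds named here.

In a functional assay on P388 cells (Mus musculus) for cytotoxicity (on this read-out lower numbers stand for stronger inhibition and higher numbers for weaker inhibition), compound 1 (`CCN1C(=O)[C@@H](C)NC(=O)[C@@H]2Cc3ccc(OC)c(c3)Oc3ccc(cc3)C[C@@H](C(=O)N2C)N(C)C(=O)[C@H](C)NC(=O)[C@H](Cc2ccc(OC)cc2)N(C)C(=O)[C@@H]1C`) gives 43.7 nM, compound 2 (`C/C=C/CN1C(=O)[C@@H](C)NC(=O)[C@@H]2Cc3ccc(OC)c(c3)Oc3ccc(cc3)C[C@@H](C(=O)N2C)N(C)C(=O)[C@H](C)NC(=O)[C@H](Cc2ccc(OC)cc2)N(C)C(=O)[C@@H]1C`) gives 9.12 nM and compound 3 (`C=C(C)CN1C(=O)[C@@H](C)NC(=O)[C@@H]2Cc3ccc(OC)c(c3)Oc3ccc(cc3)C[C@@H](C(=O)N2C)N(C)C(=O)[C@H](C)NC(=O)[C@H](Cc2ccc(OC)cc2)N(C)C(=O)[C@@H]1C`) gives 11 nM. Compound 3 cannot be told apart from compound 2, with a 1.2-fold higher number from compound 2 to compound 3 (0.08 log units; within the scatter), and it stands clearly lower than compound 1.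

Compound 4 (`COc1ccc(C[C@H]2C(=O)N[C@@H](C)C(=O)N(C)[C@H]3Cc4ccc(cc4)Oc4cc(ccc4OC)C[C@@H](C(=O)N[C@H](C)C(=O)N(C/C=C(\C)CCC=C(C)C)[C@@H](C)C(=O)N2C)N(C)C3=O)cc1`) has not yet been measured. It departs from compound 3 in one place: 2,6-dimethylhepta-1,5-dien-1-yl in place of 1-methylethenyl on a saturated chain carbon bound to an amide-type nitrogen in a ring. Cut one bond further out, the change reads 2-methylprop-2-en-1-yl to 3,7-dimethylocta-2,6-dien-1-yl.

Among the measured compounds shown here, three measured steps bear on this change. Replacing methyl with an alkenyl group gave a 4.8-fold lower number from compound 1 to compound 2 (0.68 log units; beyond the scatter) and a 4.0-fold lower number from compound 1 to compound 3 (0.60 log units; beyond the scatter), both modest and both towards lower numbers. Exchanging one short alkenyl group for the other gave no change beyond the scatter. For the measured compounds named here, none of these steps covers a chain as long as the one in compound 4, so the direction rests on weak ground. The series shows no rise so far, but the size of the new group calls for caution.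

A small upward move, probably within the scatter, is expected: a 1.5-fold higher number from compound 3 to compound 4 (0.16 log units; within the scatter). For compound 4 the estimated value is 16 nM, with an expected range of 5 nM to 60 nM.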

Compound 4, half-maximal inhibitory concentration: 49 nM
Estimate against measurement, compound 4: 3.1-fold (0.49 log units) below; low and high end bracket the measured number.
By their numbers in this assay, from the lowest: compounds 2 and 3 (each within the scatter of the next); then compounds 1 and 4 (each within the scatter of the next).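

In this assay the position on a saturated chain carbon bound to an amide-type nitrogen in a ring turns out to have a limit: the gain held by the short alkenyl groups is lost with the larger 3,7-dimethylocta-2,6-dien-1-yl group, which gives a 4.5-fold higher number from compound 3 to compound 4 (0.65 log units; beyond the scatter) and a 5.4-fold higher number from compound 2 to compound 4 (0.73 log units; beyond the scatter) on the two comparisons with those groups. Set against the smallest group in the series, the same chain gives a 1.1-fold higher number from compound 1 to compound 4 (0.05 log units; within the scatter) and so cannot be told apart from it, which means that adding carbon here does not lower the number steadily and the trend across compounds 1, 2 and 3 does not extend to compound 4. Nothing among the data shown explains this reversal.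

Between 2-methylprop-2-en-1-yl and 3,7-dimethylocta-2,6-dien-1-yl the compounds shown hold no chain of intermediate length, such as 3-methylbut-2-en-1-yl, so the point at which the number begins to rise cannot be placed. Going by these compounds, it also remains open whether the fully saturated 3,7-dimethyloctyl chain, or a chain ending in an amine or a carboxylic acid, would follow compound 4 in this assay.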